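Removing a Methyl from a Weak Cytotoxic Lactone

The compounds below may be only part of what the source reports. "The series", "measured", "known", "first", "only" and "open" are said of these compounds alone.

In a functional assay on V79 cells (Cricetulus griseus) for cytotoxicity (a lower number here means a stronger inhibitor, a higher number a weaker inhibitor), compound 1 `COc1ccc2c(c1CCC(C)C)OC(=O)CC2` reports only a limit of > 100000 nM, not a number. Compound 1 stands at the limit of > 100000 nM in this assay, at which 1 of the 2 values shown sits. Compound 2 `CC(C)CCc1c(O)ccc2ccc(=O)oc12`, built on a different core, gives 40000 nM in this assay. Compound 3 `CC(C)CCc1c(O)ccc2c1OC(=O)CC2` differs from compound 1 by hydrogen in place of methyl on an oxygen on an aromatic ring. Among the compounds with values here, no step between measured compounds is known, so the expected step from an at least 1.2-fold lower number from compound 1 to compound 3 (0.09 log units; that floor lies within the scatter) is a small gain, at most just beyond the scatter. Compound 3 is estimated at 80000 nM, in the range 30000 nM to 300000 nM.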

Compound 3, half-maximal inhibitory concentration: > 100000 nM
Compound 3: a limit, no number (the forecaster's own chance of this, stated with the estimate: 45%); middle value at least 1.2-fold (0.09 log units) from the limit.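

Compound 1 and compound 3 both end at a limit rather than a number in this assay, so no step between them can be read: the limit of > 100000 nM in this assay, at which 2 of the 3 values shown sit.
The compounds shown leave open what the change from methoxy to hydroxy does in this assay.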